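The compounds below may be only part of what the source reports. "The series", "measured", "known", "first", "only" and "open" are said of these compounds alone.

In an ADME assay on Raji cells (Homo sapiens) for cytotoxicity, with a stated time of 72 h (on this read-out lower numbers stand for an effect already at smaller amounts and higher numbers for an effect only at larger amounts of compound), compound 3 `Cc1cc(NC(=O)Nc2cccc(F)c2)c2ccccc2n1` gives > 25000 nM, which is a limit and not a number. Compound 1 `Cc1cc(NC(=O)Nc2cccc([N+](=O)[O-])c2)c2ccccc2n1` gives > 25000 nM, also a limit. Compound 2 `Cc1cc(NC(=O)Nc2cccc(C(N)=O)c2)c2ccccc2n1` gives > 25000 nM, again a limit. Among the compounds with values here, the whole series so far therefore sits at the limit of > 25000 nM in this assay, at which 3 of the 3 values shown sit, and compound 3 has no position within it beyond that.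

Compound 4 `COC(=O)c1cccc(NC(=O)Nc2cc(C)nc3ccccc23)c1` carries methoxycarbonyl in place of fluoro on an aromatic carbon. The measured steps that bear on this change are exchanges at the same aromatic carbon: a step that the two limits leave unreadable from compound 1 to compound 3, a step that the two limits leave unreadable from compound 2 to compound 3 and a step that the two limits leave unreadable from compound 1 to compound 2. None has a readable size, yet nitro, carbamoyl and fluoro all leave the read-out at the limit. No step beyond the scatter is therefore expected in this assay, and no direction can be assigned. The expected step is a number no higher from compound 3 to compound 4 (the limit leaves the size open). Compound 4 is estimated at 25000 nM, with an expected range of 12000 nM to 50000 nM, and will most likely be reported as a limit again.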

Compound 4, half-maximal effective concentration: 26000 nM
Estimate against measurement, compound 4: 1.0-fold (0.02 log units) below; low and high end bracket the measured number.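

In this assay compound 4 gives 26000 nM. Within the data shown here, no step from compound 1, compound 2 or compound 3 to compound 4 can be read. Compound 1, compound 2 and compound 3 stand only as limits. The compounds shown leave open whether any group at this aromatic carbon shifts the read-out.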